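From a phenoxybutyl ester to a pyridine ester

A few compounds are considered here, and "the series" means these few. Any claim that something is new, unique, unknown or untested is made for them only; others in the source may bear on it.

Three esters of one shared core have been measured in a functional assay on SW1573 cells (Homo sapiens) for inhibition, read by sulforhodamine B assay, with a stated time of 48 h; a higher number here means a weaker inhibitor of growth, a lower number a stronger inhibitor of growth. Compound 1 `O=C(CCCCCc1ccccc1)OCC1COCCOCCOCCOCCOCCO1` gives 78000 nM. Compound 2 `CC(C)=CC1C(C(=O)OCC2COCCOCCOCCOCCOCCO2)C1(C)C` gives 54000 nM. Compound 3 `O=C(CCCCOc1ccccc1)OCC1COCCOCCOCCOCCOCCO1` gives > 100000 nM, which is a limit of the assay rather than a number. Compound 3 thus sits at the limit of > 100000 nM in this assay, at which 1 of the 3 values shown sits. Among the measured steps, a 1.4-fold lower number from compound 1 to compound 2 (0.16 log units; within the scatter), an at least 1.2-fold higher number from compound 1 to compound 3 (0.10 log units; that floor lies within the scatter) and an at least 1.8-fold higher number from compound 2 to compound 3 (0.26 log units; that floor lies within the scatter); each changes the group on the acid side of the ester, and none moves the number beyond the scatter. Compound 4 `O=C(OCC1COCCOCCOCCOCCOCCO1)c1cccnc1` is not yet measured; it differs from compound 3 in that (pyridin-3-yl in place of 4-phenoxybutyl on a carbonyl carbon). Since the earlier exchanges of the group on the carbonyl carbon, seen in a 1.4-fold lower number from compound 1 to compound 2 (0.16 log units; within the scatter) and an at least 1.8-fold higher number from compound 2 to compound 3 (0.26 log units; that floor lies within the scatter), left growth inhibition essentially unchanged, the expected step that the limit leaves unreadable from compound 3 to compound 4 is none beyond the scatter. Compound 4 is therefore estimated at 150000 nM, with a range from 60000 nM to 400000 nM, and it may well be reported again only as a limit.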

Compound 4, concentration for 50% growth inhibition: > 100000 nM
Compound 4 was reported as a limit; the forecaster's own chance of this, stated with the estimate: 70%; the middle value lies beyond the limit too.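

Compound 4 gives > 100000 nM in this assay, which is a limit of the assay and not a number. Among these compounds, on this carbonyl carbon, pyridin-3-yl, the only group here with a nitrogen in its ring, stands in place of 4-phenoxybutyl and gives no readable number either, and the step from compound 3 cannot be read because both compounds stand at a limit: the limit of > 100000 nM in this assay, at which 2 of the 4 values shown sit. The two readable steps, an at least 1.8-fold higher number from compound 2 to compound 4 (0.26 log units; that floor lies within the scatter) and an at least 1.2-fold higher number from compound 1 to compound 4 (0.10 log units; that floor lies within the scatter), do not show that the exchange weakens growth inhibition beyond the scatter.

As far as these compounds go, how compound 3 and compound 4 rank beyond the limit stays open. Also open, from the compounds shown here alone, is whether an amine on the pyridin-3-yl ring, or a pyridin-2-yl group in its place, would give a readable number.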